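This account rests on a few compounds, and the source may have more. Where it says the series, first, only, none or still open, it means among the compounds named here.

Measured in a functional assay on HL-60 cells (Homo sapiens) for antiproliferative activity, read by MTT assay, with a stated time of 72 h; a lower number here means a stronger inhibitor, a higher number a weaker inhibitor:

- compound 1 `COc1cc(C(=O)c2sc3ccccc3c2-c2ccc(C)cc2)cc(OC)c1OC`: 1400 nM
- compound 2 `COc1ccc(-c2c(C(=O)c3cc(OC)c(OC)c(OC)c3)sc3ccccc23)cc1C`: > 10000 nM (a limit of the assay, not a number)
- compound 3 `CCOc1ccc(-c2c(C(=O)c3cc(OC)c(OC)c(OC)c3)sc3ccccc23)cc1`: 3500 nM

Only two of these three results are true numbers, and compound 3 has the higher of them, which makes it the weaker inhibitor of that pair. Its nearest neighbour is compound 1, with a 2.5-fold higher number from compound 1 to compound 3 (0.40 log units; beyond the scatter). The result for compound 2 is a limit.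

The next compound, compound 4 `CCOc1ccc(Nc2c(C(=O)c3cc(OC)c(OC)c(OC)c3)sc3ccccc23)cc1`, keeps the shared core and changes one link. (4-ethoxyphenyl)amino in place of 4-ethoxyphenyl on an aromatic carbon In words, (4-ethoxyphenyl)amino stands in place of 4-ethoxyphenyl on an aromatic carbon of the five-membered aromatic ring with 1 sulfur.

Among the measured compounds shown here, three measured steps bear on this site: a 2.5-fold higher number from compound 1 to compound 3 (0.40 log units; beyond the scatter), an at least 7.1-fold higher number from compound 1 to compound 2 (0.85 log units; beyond the scatter) and an at least 2.8-fold lower number from compound 2 to compound 3 (0.45 log units; beyond the scatter). All of them lie beyond the usual scatter, so this site responds to change. None of them introduces an amino link, which means they suggest a size for the step but no firm direction.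

A modest step is expected, leaning tentatively towards a lower number in this assay, since compound 1 at 1400 nM shows that this core can reach lower values. The expected change is a 2.9-fold lower number from compound 3 to compound 4 (0.46 log units; beyond the scatter). For compound 4 the estimated value is 1200 nM, with an expected range of 150 nM to 8000 nM.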

Compound 4, half-maximal inhibitory concentration: 500 nM
Compound 4: the middle estimate sits 2.4-fold (0.38 log units) above what was measured; the measured number falls inside the stated range.
By their numbers in this assay, from the lowest: compound 4; then compound 1; then compound 3. At a limit, above all of these: compound 2.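

Replacing 4-ethoxyphenyl with (4-ethoxyphenyl)amino on the five-membered ring brings a nitrogen and a hydrogen-bond donor to this position, and in this assay the change gives a 7.0-fold lower number from compound 3 to compound 4 (0.85 log units; beyond the scatter). This is a larger step than the one separating the two earlier exact values, and it carries the series past its previous best, with a 2.8-fold lower number from compound 1 to compound 4 (0.45 log units; beyond the scatter), so the shared core can reach lower numbers than compound 1 showed. The step of an at least 20-fold lower number from compound 2 to compound 4 (1.30 log units; beyond the scatter) gives only a minimum size, as the result for compound 2 is a limit and not a number: the limit of > 10000 nM in this assay, at which 1 of the 4 values shown sits.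

From the compounds shown here alone, with a single compound carrying the amino link, it remains open whether the same link would lower the number with the 4-methylphenyl group of compound 1 or the 4-methoxy-3-methylphenyl group of compound 2. Going by these compounds, it is also open whether the improvement depends on the amino hydrogen or simply on having a linking atom there, a question that a methylamino link, an oxygen ether link or a methylene link at this position could help to separate.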